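This account rests on a few compounds, and the source may have more. Where it says the series, first, only, none or still open, it means among the compounds named here.

Measured compounds:
compound 1 `c1ccc(-c2ccnc3c2c(-c2ccccc2)nn3-c2ccccc2)cc1` — 28200 nM
compound 2 `COc1ccc(-c2nc3c(c(-c4ccccc4)nn3-c3ccccc3)c(-c3ccc(N4CCN(C)CC4)cc3)c2C#N)cc1` — 2650 nM

In a functional assay on MCF7 cells (Homo sapiens) for inhibition, read by MTT assay, with a stated time of 48 h (a higher number here means a weaker inhibitor, a lower number a stronger inhibitor), compound 1 gives 28200 nM. That is the higher of the two numbers recorded. Compound 2, with its more elaborate substitution on the shared core, gives 2650 nM in this assay, and the gap between the two values lies beyond the usual scatter, so compound 2 is the stronger inhibitor of the pair. Going by the values given here, no single-point step between measured compounds is available, so nothing else can be read from these two numbers alone.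

Compound 3 `c1ccc(-c2nn(-c3ccccc3)c3nccc(-c4cccs4)c23)cc1` has not yet been measured in this assay. Compared with compound 1 it carries one change: thiophen-2-yl in place of phenyl on an aromatic carbon. Among the compounds with values here, with no measured step of this kind to draw on, the exchange of one aromatic ring for another of similar size is expected to leave the number roughly where compound 1 stands, with any movement staying within the scatter. The estimated step from compound 1 to compound 3 is therefore a 1.1-fold lower number from compound 1 to compound 3 (0.05 log units; within the scatter). For compound 3 the estimate in this assay is 25000 nM, within a range from 10000 nM to 60000 nM.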

Compound 3, half-maximal inhibitory concentration: 39300 nM
Estimate against measurement, compound 3: 1.6-fold (0.20 log units) below, within the range that was stated.
By their numbers in this assay, from the lowest: compound 2; then compounds 1 and 3 (each within the scatter of the next).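

In this assay, thiophen-2-yl in place of phenyl on the aromatic carbon opposite the ring nitrogen gives a 1.4-fold higher number from compound 1 to compound 3 (0.14 log units; within the scatter) and so leaves compound 1 and compound 3 indistinguishable in this assay. Going by these compounds alone, this is the first single-place step in the set, and it shows that at this position, a five-membered aromatic ring with a sulfur atom and a six-membered aromatic ring of carbon only give numbers that cannot be told apart, even though the entering group adds a hydrogen-bond acceptor by count. No measurement of any property of these two groups is at hand to bear on this result.

The compounds shown leave open whether another aromatic ring at this carbon, such as furan-2-yl or pyridin-3-yl, or a directly attached amine such as morpholine, or a carboxylic acid would stay level with compound 1 or move away from it. They also leave open which of the several structural features of compound 2 goes with its value of 2650 nM, since no compound shown separates those features one at a time.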